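The source may hold more compounds than are shown below. What is called first, only, known or untested is meant among the compounds shown, and "the series" means these compounds.

Compound 1 `CC1(C)[C@H]2CC[C@]1(C)N(Cc1cn(-c3cccc(Cl)c3)nn1)C(=O)C2` gives 60 nM in a functional assay on A549 cells (Homo sapiens) for inhibition, read by MTT assay, with a stated time of 24 h (on this read-out higher numbers stand for weaker inhibition and lower numbers for stronger inhibition), the second highest of the three numbers in hand. Compound 2 `COc1ccc(-n2cc(CN3C(=O)C[C@@H]4CC[C@@]3(C)C4(C)C)nn2)cc1` gives 50 nM, and the step of a 1.2-fold lower number from compound 1 to compound 2 (0.08 log units; within the scatter) stays within the scatter. Compound 3 `CC1(C)[C@H]2CC[C@]1(C)N(Cc1cn(-c3ccccc3Br)nn1)C(=O)C2` gives 130 nM, and the step of a 2.2-fold higher number from compound 1 to compound 3 (0.34 log units; beyond the scatter) is modest. Compound 4 `CC1(C)[C@H]2CC[C@]1(C)N(Cc1cn(-c3cccc(O)c3)nn1)C(=O)C2` differs from compound 1 by hydroxy in place of chloro on an aromatic carbon. Among the compounds with values here, no measured step exchanges chloro for hydroxy; the nearest comparison, from compound 1 to compound 2, replaces 3-chlorophenyl with 4-methoxyphenyl and stays within the scatter, while the change to 2-bromophenyl in compound 3 moves the number only modestly. The step of no change at the digits printed from compound 1 to compound 4 (within the scatter) is therefore expected to remain within the scatter, with no clear direction. Compound 4 is estimated at 60 nM, in a range from 30 nM to 130 nM.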

Compound 4, half-maximal inhibitory concentration: 180 nM
Beside the measured number, compound 4's estimate is 3.0-fold (0.48 log units) below it; measured number outside the range, above it.
By their numbers in this assay, from the lowest: compounds 2 and 1 (each within the scatter of the next); then compounds 3 and 4 (each within the scatter of the next).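

In this assay, hydroxy in place of chloro on this aromatic carbon, meta to a large group, is not a silent exchange (a 3.0-fold higher number from compound 1 to compound 4 (0.48 log units; beyond the scatter)), unlike the step between compounds 1 and 2. The gap to the 4-methoxyphenyl group is similar (a 3.6-fold higher number from compound 2 to compound 4 (0.56 log units; beyond the scatter)), while the 2-bromophenyl group stays within the scatter (a 1.4-fold higher number from compound 3 to compound 4 (0.14 log units; within the scatter)), so compound 4 groups with compound 3. No evidence given here accounts for this shift. As far as these compounds go, whether an amine or a carboxylic acid on this same carbon would group with compound 1 or with compound 4 remains open.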